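Methylation of the aromatic amine: notes on compound 4

The compounds below may be only part of what the source reports. "The series", "measured", "known", "first", "only" and "open" are said of these compounds alone.

Compound 1 `CS(=O)(=O)N1CC(CCl)c2ccc(O)cc21` gives 20000 nM in a functional assay on CHO-AA8 cells (Cricetulus griseus) for cytotoxicity, with a stated time of 4 h; a higher number here means a weaker inhibitor, a lower number a stronger inhibitor.
Compound 2 `CS(=O)(=O)N1CC(CCl)c2ccc(N)cc21` gives 158000 nM in this assay.
Compound 3 `CNc1ccc2c(c1)N(S(C)(=O)=O)CC2CCl` gives 50000 nM in this assay.

Compound 3 stands second highest of the three numbers, with a 2.5-fold higher number from compound 1 to compound 3 (0.40 log units; beyond the scatter) and a 3.2-fold lower number from compound 2 to compound 3 (0.50 log units; beyond the scatter). Compound 4 `CN(C)c1ccc2c(c1)N(S(C)(=O)=O)CC2CCl` differs from compound 3 by methyl in place of hydrogen on a nitrogen on an aromatic ring. Among the measured compounds shown here, the only measured step of the same kind is a 3.2-fold lower number from compound 2 to compound 3 (0.50 log units; beyond the scatter), a modest drop in the number; the other steps exchange the whole group and bear less directly. A second methyl on the same nitrogen is not covered by any measured pair, so the expected shift is smaller and uncertain. In this assay compound 4 is estimated at 30000 nM, range 10000 nM to 90000 nM, meaning an expected step of a 1.7-fold lower number from compound 3 to compound 4 (0.22 log units; within the scatter) from compound 3.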

Compound 4, half-maximal inhibitory concentration: 72000 nM
The estimate for compound 4 lay 2.4-fold (0.38 log units) below the measured number, and the stated range covers the measured number.
By their numbers in this assay, from the lowest: compound 1; then compounds 3 and 4 (each within the scatter of the next); then compound 2.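

In this assay the second methyl on this nitrogen shows a 1.4-fold higher number from compound 3 to compound 4 (0.16 log units; within the scatter) and so adds no separable change, while the first methyl shows a 3.2-fold lower number from compound 2 to compound 3 (0.50 log units; beyond the scatter) and does move the number. Dimethylamino in place of amino still gives a 2.2-fold lower number from compound 2 to compound 4 (0.34 log units; beyond the scatter) overall, yet dimethylamino in place of hydroxy gives a 3.6-fold higher number from compound 1 to compound 4 (0.56 log units; beyond the scatter) and leaves compound 4 on the weaker side of compound 1. On these data alone, whether an ethyl group or a longer chain on this nitrogen, or an acetyl group there, shifts the number remains open. Nothing available on these compounds accounts for the size of these steps.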